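A five-membered ring exchanged on a shared core

The source may report more compounds than this note shows. Statements on the series, on what has been measured and on what is new or still open speak of the compounds shown alone.

Three compounds of one series have numbers in a physicochemical assay for lipophilicity, at pH 7.4 (a higher number here means a more lipophilic compound, a lower number a more polar compound), so far. Compound 3 (`Cc1cc(C)c(CN2CCc3c(Cl)cc(-c4c(C)n[nH]c4C)c(Cl)c3C2=O)c(=O)[nH]1`) stands highest at 3.4 and lies beyond the scatter from the other two. Compound 1 (`Cc1cc(C)c(CN2CCc3c(Cl)cc(-c4cn[nH]c4)c(Cl)c3C2=O)c(=O)[nH]1`) gives 3 on that scale, and compound 2 (`Cc1cc(C)c(CN2CCc3ccc(-c4c(C)noc4C)c(Cl)c3C2=O)c(=O)[nH]1`) gives 2.6 as the lowest number. Compound 4 (`Cc1cc(C)c(CN2CCc3c(Cl)cc(-c4c(C)noc4C)c(Cl)c3C2=O)c(=O)[nH]1`) has not been measured. It carries 3,5-dimethyl-1,2-oxazol-4-yl in place of 3,5-dimethyl-1H-pyrazol-4-yl on an aromatic carbon, ortho to a chloro group. Within the data shown here, the only measured one-place step, a number 0.40 log units higher from compound 1 to compound 3 (beyond the scatter) in this assay terms, is a modest one, but it is a different exchange and offers only a sense of scale. Among the measured compounds shown here, no measured step exchanges these two groups. Compound 2 also carries 3,5-dimethyl-1,2-oxazol-4-yl, but it differs from compound 3 in more than one place, so it cannot isolate this change. The expected change is no change at the digits printed from compound 3 to compound 4 (within the scatter) and should stay within the scatter, with no firm direction. For compound 4 the estimated value is 3.4 within an expected range from 3 to 3.8 on this scale.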

Compound 4, distribution coefficient: 3.1
Beside the measured number, compound 4's estimate is 0.30 log units above it; low and high end bracket the measured number.
By their numbers in this assay, from the lowest: compound 2; then compounds 1, 4 and 3 (each within the scatter of the next, the first and the last beyond it).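

Among these compounds, at the aromatic carbon ortho to a chloro group, the first direct reading of this exchange in this assay is a number 0.30 log units lower from compound 3 to compound 4 (within the scatter) and so shows that 3,5-dimethyl-1,2-oxazol-4-yl, which counts no hydrogen-bond donor, can stand in place of 3,5-dimethyl-1H-pyrazol-4-yl, which counts one, without a shift beyond the scatter. Set against 1H-pyrazol-4-yl, the same group gives a number 0.10 log units higher from compound 1 to compound 4 (within the scatter) while chloro in place of hydrogen on an aromatic carbon gives a number 0.50 log units higher from compound 2 to compound 4 (beyond the scatter) and is the only one of these new steps beyond the scatter. Nothing at hand explains these numbers. On these data alone, whether the exchange reads the same on the core of compound 2, which has hydrogen in place of that chloro group, stays open. Nor do the compounds shown tell what an amine or a carboxylic acid at this position would give.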